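The source may report more compounds than this note shows. Statements on the series, on what has been measured and on what is new or still open speak of the compounds shown alone.

Of the compounds shown here, three have numbers so far in a functional assay on SKBR cells (Homo sapiens) for cytotoxicity, read by resazurin assay, with a stated time of 72 h; on this read-out higher numbers stand for weaker inhibition and lower numbers for stronger inhibition. Compound 1 (`COc1cc(/C=C/C(=O)OCCCCCCO[N+](=O)[O-])ccc1O`) gives 15200 nM, compound 2 (`O=C(/C=C/c1ccc(OCCCCO[N+](=O)[O-])c(O)c1)OCCCCO[N+](=O)[O-]`) gives 3230 nM, and compound 3 (`O=C(/C=C/c1ccc(O)c(O)c1)OCc1c(-c2ccccc2)no[n+]1[O-]`) gives 700 nM. Compound 3 therefore stands lowest of the three, and its gap to each of the others lies beyond the scatter.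

Compound 4 (`COc1cc(/C=C/C(=O)OCc2c(-c3ccccc3)no[n+]2[O-])ccc1O`) departs from compound 3 in one place: methyl in place of hydrogen on an oxygen on an aromatic ring. This puts methyl in place of hydrogen on an oxygen on an aromatic ring, turning 3,4-dihydroxyphenyl into 4-hydroxy-3-methoxyphenyl. Among the compounds with values here, no measured pair isolates this change, so its size can only be judged loosely. Within the data shown here, the one measured compound carrying 4-hydroxy-3-methoxyphenyl is compound 1, at 15200 nM, which offers weak support for expecting a move toward weaker inhibition in this assay. A modest rise is expected, close to the edge of the scatter, and the estimated step is a 2.1-fold higher number from compound 3 to compound 4 (0.33 log units; beyond the scatter). For compound 4 the estimated value is 1500 nM, with an expected range of 550 nM to 5000 nM.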

Compound 4, half-maximal inhibitory concentration: 4980 nM
Compound 4: middle estimate off by 3.3-fold (0.52 log units), on the low side; measured number inside the range.
By their numbers in this assay, from the lowest: compound 3; then compounds 2 and 4 (each within the scatter of the next); then compound 1.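

The series now has its first pair that isolates a single change. In this assay, methyl in place of hydrogen on an oxygen on an aromatic ring, turning 3,4-dihydroxyphenyl into 4-hydroxy-3-methoxyphenyl, gives a 7.1-fold higher number from compound 3 to compound 4 (0.85 log units; beyond the scatter). This position is therefore sensitive in this scaffold: adding one heavy atom, with no ring and no net charge, is enough to weaken inhibition beyond the scatter, although no measurement here accounts for the loss.

From the compounds shown here alone, it remains open whether a larger group on that oxygen, such as ethyl, would move the number further, or whether an amine in place of the hydroxy would restore inhibition. Within the data shown here, whether the same step holds with the ester chain of compound 1 also stays unresolved, as no pair isolates the change there.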